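5-methylpyridin-2-yl in place of 3-methylphenyl

A few compounds are considered here, and "the series" means these few. Any claim that something is new, unique, unknown or untested is made for them only; others in the source may bear on it.

Going by the values given here, in an ADME assay on microsomes from liver (Homo sapiens) for metabolic stability (on this read-out lower numbers stand for slow clearance and higher numbers for fast clearance), compound 2 (`Cc1cccc([C@H](C)NC(=O)Cn2nnc3ccccc3c2=O)c1`) gives 11 mL/min/kg, the only true number in the set. Compound 1 (`C[C@@H](NC(=O)Cn1nnc2ccccc2c1=O)c1ccc(Cl)cc1`) reads < 9.9 mL/min/kg, which is a limit. Compound 3 (`Cc1ccc([C@H](C)NC(=O)Cn2nnc3ccccc3c2=O)cc1`) reads < 9.9 mL/min/kg, likewise a limit. The readings therefore crowd against (the limit of < 9.9 mL/min/kg in this assay, at which 2 of the 3 values shown sit).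

Compound 4 (`Cc1ccc([C@H](C)NC(=O)Cn2nnc3ccccc3c2=O)nc1`) differs from compound 2 by 5-methylpyridin-2-yl in place of 3-methylphenyl on a saturated chain carbon bound to an amide-type nitrogen and a saturated chain carbon. Among the compounds with values here, the one measured step that bears on this aryl position is an at least 1.1-fold lower number from compound 2 to compound 3 (0.04 log units; that floor lies within the scatter), with 4-methylphenyl entering for 3-methylphenyl. Within the data shown here, with that step as the only guide, no shift beyond the scatter is expected in this assay. The expected step is a 1.1-fold lower number from compound 2 to compound 4 (0.04 log units; within the scatter). For compound 4 the estimated value is 10 mL/min/kg, with an expected range of 5 mL/min/kg to 20 mL/min/kg.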

Compound 4, clearance: < 9.9 mL/min/kg
Compound 4 ended at the assay's limit (the forecaster's own chance of this, stated with the estimate: 50%); middle value at least 1.0-fold (0.00 log units) from the limit.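

In this assay, 5-methylpyridin-2-yl in place of 3-methylphenyl gives an at least 1.1-fold lower number from compound 2 to compound 4 (0.04 log units; that floor lies within the scatter). A six-membered aromatic ring with a hetero atom is therefore accepted at this place with no step beyond the scatter, while the step between compound 3 and compound 4 cannot be read. The read-out leaves little room to separate these aryl groups: the limit of < 9.9 mL/min/kg in this assay, at which 3 of the 4 values shown sit.

Going by these compounds, whether an amine or a carboxylic acid on this aryl ring would move clearance clear of that limit remains open. So does the effect of a longer chain in place of the methyl group.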